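Chain Lengthening in Two Related Cores: Effect on Cell Activity

The source may report more compounds than this note shows. Statements on the series, on what has been measured and on what is new or still open speak of the compounds shown alone.

Measured compounds, in a functional assay on cells (Lymphocyte), read by a luciferase reporter and ATP content, with a stated time of 48 h, tested at 25 uM; a lower number here means a stronger effect, a higher number a weaker effect of the compound at the concentration tested:
compound 1, `CCCCCCCCCCc1c(C)c(N(C)C)nc(C)c1O`: 2%
compound 2, `CCCCCCCCCCc1nc(N(C)C)c(C)c(C)c1O`: 13%
compound 3, `CCCCCCCCCCCCCCCCCCCc1c(C)c(N(C)C)nc(C)c1O`: 86%

Compound 1 and compound 2 are built from the same atoms joined differently; the difference between the two cores is not broken down here. In this assay compound 2 stands second highest of the three, with compound 1 nearest and compound 3 furthest away. Compound 3 arises from compound 1 by nonyl in place of hydrogen on a saturated chain carbon, ten or more bonds along the chain from an aromatic carbon, and this change carried a step of a number 84 percentage points higher from compound 1 to compound 3 (beyond the scatter), a large move toward a weaker effect.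

Compound 4, `CCCCCCCCCCCCCCCCCCCc1nc(N(C)C)c(C)c(C)c1O`, has not yet been measured. It arises from compound 2 by nonyl in place of hydrogen on a saturated chain carbon, ten or more bonds along the chain from an aromatic carbon, the same change as from compound 1 to compound 3. Within the data shown here, on the strength of the single earlier step of a number 84 percentage points higher from compound 1 to compound 3 (beyond the scatter), the step in this assay from compound 2 to compound 4 is expected to be a number 75 percentage points higher from compound 2 to compound 4 (beyond the scatter), again toward a weaker effect. Compound 4 is therefore estimated at 88%, with a likely range from 70% to 100%; this rests on one pair only.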

Compound 4, a percentage reported as activity, at one concentration (the size of the read-out at that concentration, not a potency): 99%
The estimate for compound 4 lay 11 percentage points below the measured number; the range from low to high includes it.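

In this assay, nonyl in place of hydrogen on a saturated chain carbon, ten or more bonds along the chain from an aromatic carbon, gave a number 86 percentage points higher from compound 2 to compound 4 (beyond the scatter), and the change carried from the core of compound 1 to the core of compound 2 with its size preserved: the same change on two cores in this assay, a number 84 percentage points higher (beyond the scatter) from compound 1 to compound 3 and a number 86 percentage points higher (beyond the scatter) from compound 2 to compound 4, 2 percentage points apart, within the scatter of two such steps Across these two cores, then, the step read on one core held on the other, and the difference between the cores did not alter the size of the step. Among these compounds, this rests on only two pairs, one change and one assay at a single concentration, so it does not show that the match would hold on any further core or for any other change to the chain, and it does not explain why the effect weakens.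

The compounds shown leave open where between the chains of compound 1 and compound 3 the effect is lost. They also leave open whether a shorter chain, or a chain ending in a carboxylic acid or an amine, would behave alike on both cores.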